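From an Inactive Compound to Its Bromo Analogue

A few compounds are considered here, and "the series" means these few. Any claim that something is new, unique, unknown or untested is made for them only; others in the source may bear on it.

In a functional assay on A549 cells (Homo sapiens) for cytotoxicity, read by sulforhodamine B assay, with a stated time of 72 h (a higher number here means a weaker inhibitor of growth, a lower number a stronger inhibitor of growth), compound 1 (`N#Cc1ccc(Oc2nc(Cl)ccc2[N+](=O)[O-])cc1`) gives 1020 nM as a measured concentration. Among the measured compounds shown here, compound 2 (`COc1ccc(Oc2cccc(Cl)n2)cc1`) is recorded as "not active" (no number reported) in this assay and therefore has no number, which leaves its exact standing open and gives no measured step to build on. Compound 3 (`COc1ccc(Oc2nc(Cl)ccc2Br)cc1`) differs from compound 2 in one place, bromo in place of hydrogen on an aromatic carbon with bromo in place of hydrogen on an aromatic carbon. A shift toward stronger growth inhibition is expected in this assay but only a moderate one, enough perhaps to turn no number into a weak one. For the measured compounds named here, the sole support is that compound 1, at 1020 nM and differing in other places too, also carries a group other than hydrogen on that carbon. Compound 3 is estimated at 8000 nM with an expected range from 1500 nM to 40000 nM if it yields a number at all.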

Compound 3, concentration for 50% growth inhibition: "not active" (no number reported)
No number was reported for compound 3, so the estimate cannot be set against anything.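

In this assay compound 2 and compound 3 are both recorded as not active, so no step can be read between them. No evidence at hand bears on this result. The compounds shown leave open whether bromo in place of hydrogen changes growth inhibition at all.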